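A few compounds are considered here, and "the series" means these few. Any claim that something is new, unique, unknown or untested is made for them only; others in the source may bear on it.

In a functional assay on SNB-19 cells (Homo sapiens) for inhibition, read by sulforhodamine B assay, with a stated time of 48 h, tested at 10 uM (a higher number here means more inhibition of growth at the concentration tested, a lower number less inhibition of growth), compound 1 (`COc1ccc(-c2nc3sc(-c4ccccc4)cn3n2)cc1`) gives 34% and compound 2 (`Clc1ccc(-c2cn3nc(-c4ccccc4)nc3s2)cc1`) gives 57% as the higher of the two numbers, a gap beyond the scatter. The step followed here leads from compound 2 to compound 3 (`COc1ccc(-c2nc3sc(-c4ccc(Cl)cc4)cn3n2)cc1`) and is methoxy in place of hydrogen on an aromatic carbon with methoxy in place of hydrogen on an aromatic carbon. For the measured compounds named here, no measured pair shows this change alone, so its size in this assay remains open. Going by the values given here, the only hint is that compound 1, which also carries methoxy, gives 34% as the lower number. A modest fall in growth inhibition is therefore expected, close to the scatter and possibly within it. The estimated step of a number 11 percentage points lower from compound 2 to compound 3 (beyond the scatter) is uncertain in size. For compound 3 the estimated value is 46% with an expected range from 28% to 64% in this series.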

Compound 3, percent growth inhibition at one concentration: -1.95%
Beside the measured number, compound 3's estimate is 48 percentage points above it; the whole stated range lies above it.
By their numbers in this assay, from the lowest: compound 3; then compound 1; then compound 2.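

In this assay methoxy in place of hydrogen on the aromatic carbon para to a large group gives a number 59 percentage points lower from compound 2 to compound 3 (beyond the scatter) and leaves compound 3 at -1.95% as the lowest of the three numbers. From the other side, chloro in place of hydrogen gives a number 36 percentage points lower from compound 1 to compound 3 (beyond the scatter) so each group, added to a compound carrying the other, brings a large fall, and the pair together leaves no growth inhibition at the concentration tested. Nothing at hand says why the two groups together behave this way.

An amine, a hydroxyl group or a longer chain such as ethoxy at this carbon, with the chloro kept, would show whether the fall belongs to methoxy itself or to any group at this place.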